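A few compounds are considered here, and "the series" means these few. Any claim that something is new, unique, unknown or untested is made for them only; others in the source may bear on it.

Of the compounds shown here, three have been measured in a functional assay on the whole organism for activation, with Mus musculus as the target; on this read-out lower numbers stand for an effect already at smaller amounts and higher numbers for an effect only at larger amounts of compound. Compound 1 `Nc1ncnc2c1nc(O)n2Cc1ccc(Cl)cc1` gives 30 mg/kg, and compound 3 `Nc1ncnc2c1nc(O)n2Cc1ccc(F)cc1` gives 30 mg/kg; the step of no change at the digits printed from compound 1 to compound 3 (within the scatter) shows that exchanging the halogen on that aromatic carbon left the read-out where it was. Compound 2 `CSc1nc(N)c2nc(O)n(Cc3ccccc3)c2n1` gives 0.1 mg/kg in this assay, the lowest of the three numbers, with both compound 1 and compound 3 standing well beyond the scatter above it.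

Compound 4 `CCCCc1nc(N)c2nc(O)n(Cc3ccccc3)c2n1` is not yet measured. It differs from compound 2 in one place: butyl in place of methylsulfanyl on an aromatic carbon. Within the data shown here, no measured step bears on this change. Among the measured compounds shown here, the only measured step, from compound 1 to compound 3, concerns a different place in the structure and was flat, so it says nothing about swapping the group on the shared core. The two groups differ in what they count, and the data give no guide to the size or direction of the effect.

Compound 4 is therefore expected to stay near compound 2, with a modest drift upward allowed for the change in group, an estimated step of a 3.0-fold higher number from compound 2 to compound 4 (0.48 log units; beyond the scatter). The estimate for compound 4 in this assay is 0.3 mg/kg, within a range from 0.05 mg/kg to 3 mg/kg.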

Compound 4, minimum effective dose: 0.3 mg/kg
Compound 4: the middle estimate sits on the measured number at the digits printed; the measured number falls inside the stated range.
By their numbers in this assay, from the lowest: compound 2; then compound 4; then compounds 1 and 3 (each within the scatter of the next).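

Among these compounds, the result gives the first reading at this position, on the aromatic carbon between two ring nitrogen atoms, since the only earlier step concerned a halogen elsewhere in the structure. In this assay, butyl in place of methylsulfanyl gives a 3.0-fold higher number from compound 2 to compound 4 (0.48 log units; beyond the scatter), so this change is modest but does move the number beyond the scatter, and the position tolerates the loss of the sulfur and the hydrogen-bond acceptor counted for methylsulfanyl while compound 4 stays at 0.3 mg/kg in the same low range. Nothing on hand accounts for the direction or size of this step.

This single exchange changes the atom attached to the ring and the length of the group together, so it cannot separate the two, and a propyl or pentyl chain, an ethylsulfanyl group or an amine at this position would be needed to tell how the number follows each. It also leaves open whether the chloro or fluoro group of compound 1 and compound 3 would shift the number on the benzyl group of compound 4.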